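The source may report more compounds than this note shows. Statements on the series, on what has been measured and on what is new or still open speak of the compounds shown alone.

Among the compounds with values here, in a functional assay on SW1573 cells (Homo sapiens) for antiproliferative activity, read by sulforhodamine B assay, with a stated time of 48 h (on this read-out higher numbers stand for weaker inhibition of growth and lower numbers for stronger inhibition of growth), three compounds on a shared core have numbers so far. Compound 1 `CCCCC(C#CC(=O)OC)O/C=C/C(=O)OC`, carrying butyl, gives 240 nM. Compound 2 `CCCCCC(C#CC(=O)OC)O/C=C/C(=O)OC`, carrying pentyl, gives 1700 nM. Compound 3 `COC(=O)C#CC(O/C=C/C(=O)OC)C(C)(C)C`, carrying tert-butyl, gives 3000 nM. Two steps place compound 3: a 13-fold higher number from compound 1 to compound 3 (1.10 log units; beyond the scatter), and a 1.8-fold higher number from compound 2 to compound 3 (0.25 log units; within the scatter).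

Within the data shown here, compound 4 `CCC(C)C(C#CC(=O)OC)O/C=C/C(=O)OC` changes only this group: sec-butyl in place of tert-butyl on a saturated chain carbon bound to an oxygen on an unsaturated carbon and a triple-bonded carbon. The atoms are the same, joined differently. Among the measured compounds shown here, no measured compound carries sec-butyl, so the expectation rests on the butyl of compound 1 at 240 nM and the tert-butyl of compound 3 at 3000 nM. Also relevant is a 7.1-fold higher number from compound 1 to compound 2 (0.85 log units; beyond the scatter), which shows that a methyl on the chain can move the number beyond the scatter. A position between these two end points is expected, so a moderate move toward stronger inhibition of growth is expected in this assay. The estimated step is a 3.8-fold lower number from compound 3 to compound 4 (0.57 log units; beyond the scatter). For compound 4 the expected value is 800 nM, with an estimated range of 250 nM to 2500 nM.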

Compound 4, concentration for 50% growth inhibition: 910 nM
Compound 4: the middle estimate sits 1.1-fold (0.06 log units) below what was measured; the measured number falls inside the stated range.
By their numbers in this assay, from the lowest: compound 1; then compounds 4, 2 and 3 (each within the scatter of the next, the first and the last beyond it).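

In this assay, butyl, sec-butyl and tert-butyl can be compared as differently joined groups at this position: a 3.3-fold lower number from compound 3 to compound 4 (0.52 log units; beyond the scatter), and a 3.8-fold higher number from compound 1 to compound 4 (0.58 log units; beyond the scatter). Across these three compounds, the number therefore rises beyond the scatter in the order butyl, sec-butyl, tert-butyl, whereas sec-butyl and pentyl are not separated, with a 1.9-fold lower number from compound 2 to compound 4 (0.27 log units; within the scatter). Nothing at hand accounts for these differences. 

The compounds shown leave open where a shorter propyl chain or a longer hexyl chain would fall relative to butyl and pentyl. They also leave open whether a cyclopentyl ring at this saturated chain carbon would behave like the open-chain branched groups.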